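A few compounds are considered here, and "the series" means these few. Any claim that something is new, unique, unknown or untested is made for them only; others in the source may bear on it.

Three compounds share one core and differ only in the group on the carbonyl carbon of the amide. Compound 1 `COc1ccc(-c2cnc(NC(=O)c3ccccc3F)n2C)cc1` carries 2-fluorophenyl there. In a toxicity assay on THP-1 cells (Homo sapiens) for inhibition (on this read-out lower numbers stand for higher toxicity in this test and higher numbers for lower toxicity in this test), compound 1 gives > 100000 nM, which is a limit of the assay and not a number. Compound 2 `COc1ccc(-c2cnc(NC(=O)C3CCCC3)n2C)cc1` carries cyclopentyl in place of 2-fluorophenyl on a carbonyl carbon. In this assay compound 2 gives > 100000 nM, again a limit. Compound 3 `COc1ccc(-c2cnc(NC(=O)c3ccc(O)cc3)n2C)cc1` carries 4-hydroxyphenyl on that carbonyl carbon. In this assay compound 3 gives > 100000 nM, also a limit. Compound 3 thus stands at the same limit as the other two values shown, and no number separates any of them. All three steps between them are unreadable for that reason: a step that the two limits leave unreadable from compound 1 to compound 2, a step that the two limits leave unreadable from compound 1 to compound 3, a step that the two limits leave unreadable from compound 2 to compound 3.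

Compound 4 `COc1ccc(-c2cnc(NC(=O)c3ccncc3)n2C)cc1` is not yet measured. Its difference from compound 3 is pyridin-4-yl in place of 4-hydroxyphenyl on a carbonyl carbon. For the measured compounds named here, the steps that bear on this change are the earlier exchanges of the group on the carbonyl carbon, and none of them gave a readable size, because of the limit of > 100000 nM in this assay, at which 3 of the 3 values shown sit. No direction can therefore be read for this assay, and the expectation is that compound 4 also reaches that limit. Compound 4 is estimated at 150000 nM, within 50000 nM to 500000 nM, which is expected to mean a step that the limit leaves unreadable from compound 3 to compound 4.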

Compound 4, half-maximal cytotoxic concentration: > 100000 nM
Compound 4: only a limit was reported; the forecaster's own chance of this, stated with the estimate: 80%; the middle value lies beyond the limit too.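

The steps to compound 4 from compound 1, compound 2 and compound 3 cannot be read, and no size can be given for any of them, because all four compounds stop at the same point: the limit of > 100000 nM in this assay, at which 4 of the 4 values shown sit. The compounds shown leave open whether any group on that carbonyl carbon would give a number rather than a limit in this assay.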